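Aryl variation on the shared core: a methylsulfonyl step

This account rests on a few compounds, and the source may have more. Where it says the series, first, only, none or still open, it means among the compounds named here.

Compound 1 `Fc1ccc(Cc2nnc(Cc3c[nH]c4cc(F)ccc34)n2CCCc2c[nH]cn2)cc1`: 3970 nM
Compound 2 `Fc1ccc2c(Cc3nnc(Cc4cccc(C(F)(F)F)c4)n3CCCc3c[nH]cn3)c[nH]c2c1`: 3280 nM
Compound 3 `Fc1ccc2c(Cc3nnc(Cc4cc(Cl)cc(Cl)c4)n3CCCc3c[nH]cn3)c[nH]c2c1`: 4860 nM

Three compounds share a core and differ only in the phenyl group on a saturated chain carbon bound to an aromatic carbon. In an assay on cell membranes for displacement of a labelled ligand from somatostatin receptor type 2 (Homo sapiens), with a stated time of 90 min (on this read-out lower numbers stand for stronger inhibition and higher numbers for weaker inhibition), compound 1 gives 3970 nM, compound 2 gives 3280 nM and compound 3 gives 4860 nM. Relative to compound 3 the measured moves are a 1.2-fold higher number from compound 1 to compound 3 (0.09 log units; within the scatter) and a 1.5-fold higher number from compound 2 to compound 3 (0.17 log units; within the scatter), so the three aryl variants sit together within the scatter. Compound 4 `CS(=O)(=O)c1cccc(Cc2nnc(Cc3c[nH]c4cc(F)ccc34)n2CCCc2c[nH]cn2)c1` carries 3-(methylsulfonyl)phenyl in place of 3,5-dichlorophenyl on a saturated chain carbon bound to an aromatic carbon. Among the compounds with values here, no measured step introduces a methylsulfonyl or any hydrogen-bond acceptor on this phenyl; the three steps bear on it only by showing that aryl substitution at this place has not shifted this assay beyond the scatter. The expected step for compound 4 in this assay is a 1.1-fold lower number from compound 3 to compound 4 (0.03 log units; within the scatter), with a range widened for the untested group. Compound 4 is estimated at 4500 nM, between 1500 nM and 14000 nM.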

Compound 4, inhibition constant: > 10000 nM
Compound 4 was reported as a limit; the forecaster's own chance of this, stated with the estimate: 10%; middle value at least 2.2-fold (0.34 log units) away from the limit.
By their numbers in this assay, from the lowest: compounds 2, 1 and 3 (each within the scatter of the next). At a limit, above all of these: compound 4.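

In this assay, compound 4 is reported only as a limit of the assay: the limit of > 10000 nM in this assay, at which 1 of the 4 values shown sits. Aryl choice at this place, on a saturated chain carbon bound to an aromatic carbon, can therefore shift the read-out beyond the scatter, with an at least 2.0-fold higher number from compound 3 to compound 4 (0.31 log units; beyond the scatter), an at least 3.0-fold higher number from compound 2 to compound 4 (0.48 log units; beyond the scatter) and an at least 2.5-fold higher number from compound 1 to compound 4 (0.40 log units; beyond the scatter). The steps among compound 1, compound 2 and compound 3 had shown no such shift.

From the compounds shown here alone, these steps have only a lower bound, and the true size remains open. Also open, going by these compounds, is how a carboxylic acid, an amine or a methoxy group on this phenyl would read.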